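The source may report more compounds than this note shows. Statements on the series, on what has been measured and on what is new or still open speak of the compounds shown alone.

In a functional assay on HeLa cells (Homo sapiens) for antiproliferative activity, read by MTT assay, with a stated time of 48 h (on this read-out lower numbers stand for stronger inhibition and higher numbers for weaker inhibition), compound 1 `Fc1ccc(CSc2nnc(-c3cnccn3)s2)c(F)c1` gives 20900 nM. For compound 2 `Brc1ccccc1CSc1nnc(-c2cnccn2)n1-c1ccccc1`, the read-out is only a limit of the assay, > 50000 nM. Compound 3 `Fc1ccc(CSc2nnc(-c3cnccn3)n2-c2ccccc2)c(F)c1` keeps the core of compound 2 but has 2,4-difluorophenyl in place of 2-bromophenyl on a saturated chain carbon bound to a sulfur. Within the data shown here, no measured step isolates this change, but compound 1, which bears the 2,4-difluorobenzyl group on a different core, gives 20900 nM, so a small gain in this assay is expected. The expected step of an at least 1.4-fold lower number from compound 2 to compound 3 (0.15 log units; that floor lies within the scatter) runs towards lower numbers. Compound 3 is estimated at 35000 nM, with an expected range of 14000 nM to 70000 nM.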

Compound 3, half-maximal inhibitory concentration: 12500 nM
The estimate for compound 3 lay 2.8-fold (0.45 log units) above the measured number; the whole stated range lies above it.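

On a saturated chain carbon bound to a sulfur, 2,4-difluorophenyl in place of 2-bromophenyl gives an at least 4.0-fold lower number from compound 2 to compound 3 (0.60 log units; beyond the scatter) in this assay, so the group at this position does affect the read-out. The earlier compounds shown here offered no pair that isolated this change. The true size of the step stays open, as it is only a floor: the limit of > 50000 nM in this assay, at which 1 of the 3 values shown sits.

The compounds shown leave open whether a single fluorine, a methoxy group or an amine on that phenyl ring would read the same way. They also leave open what a longer chain between the sulfur and the ring would do.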